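Carbamate series: cytotoxicity on liver cells, one ring swapped

The compounds below may be only part of what the source reports. "The series", "measured", "known", "first", "only" and "open" are said of these compounds alone.

Measured so far:
compound 1, `CN(C)CCCCN(C(=O)O)c1ccccc1Cn1nc(-c2ccc(F)cc2)c2ccccc2c1=O`: 48500 nM
compound 2, `CN(C)CCCCC(=O)Nc1ccc(CN2N=C(c3ccc(F)cc3)C3C=CC=CC3C2=O)cc1`: 77700 nM
compound 3, `CN(C)CCCCOC(=O)Nc1ccc(Cn2nc(-c3cncnc3)c3ccccc3c2=O)cc1`: 65300 nM

Of the compounds shown here, three sharing a related core have been tested in an ADME assay on Huh-7 cells (Homo sapiens) for cytotoxicity, read by MTT assay, with a stated time of 48 h; a lower number here means that less compound is tolerated, a higher number that more compound is tolerated. Compound 1 gives 48500 nM, compound 2 gives 77700 nM, and compound 3 gives 65300 nM. Compound 3 holds the second highest of the three numbers; its nearest neighbour is compound 2, its furthest compound 1, and both gaps lie within the scatter, so the three compounds cannot be told apart in this assay.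

Compound 4, `CN(C)CCCCOC(=O)Nc1ccc(Cn2nc(-c3ccc(C#N)cc3)c3ccccc3c2=O)cc1`, has not yet been measured. It differs from compound 3 in one place: 4-cyanophenyl in place of pyrimidin-5-yl on an aromatic carbon. Within the data shown here, no step between measured compounds speaks to this kind of exchange, and the three measured values sit close together. Compound 4 is therefore expected to show no step beyond the scatter, with an estimated step of a 1.2-fold lower number from compound 3 to compound 4 (0.07 log units; within the scatter). For compound 4 the estimate in this assay is 55000 nM, within a range from 25000 nM to 120000 nM.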

Compound 4, half-maximal cytotoxic concentration: 37000 nM
The estimate for compound 4 lay 1.5-fold (0.17 log units) above the measured number, within the range that was stated.
By their numbers in this assay, from the lowest: compounds 4, 1, 3 and 2 (each within the scatter of the next, the first and the last beyond it).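

In this assay, among these compounds, placing 4-cyanophenyl where pyrimidin-5-yl stood gives a 1.8-fold lower number from compound 3 to compound 4 (0.25 log units; within the scatter), a step that stays within the scatter and is the first single-place exchange the series offers. At this position, on an aromatic carbon next to the ring nitrogen, a six-membered aromatic ring of carbon only bearing a nitrile can thus stand in for a ring with two nitrogens without a difference the assay can resolve. Nothing at hand bears on why this step has the size it has.

Still open, going by these compounds, is whether a group of another kind at this position, such as an amine or a carboxylic acid, would give a step beyond the scatter. On these data alone, it is equally open whether a plain phenyl or a morpholine ring here would stay as close to compound 3 as compound 4 does.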